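The compounds below may be only part of what the source reports. "The series", "measured", "known", "first", "only" and "open" are said of these compounds alone.

Of the compounds shown here, three have been measured so far. Compound 1 `CCc1nc(NC(CC)CC)cnc1-c1ccc(Cl)cc1Cl`, compound 2 `CCc1nc(-c2ccc(OC)cc2O)c(CC)nc1NC(CC)CC` and compound 3 `CCc1nc(-c2ccc(OC(F)(F)F)cc2OC)c(OC)nc1NC(CC)CC` were tested in an assay on IMR-32 cells for displacement of a labelled ligand from corticotropin-releasing factor receptor 1 (Homo sapiens), read by scintillation counting, with a stated time of 2 h (on this read-out higher numbers stand for weaker inhibition and lower numbers for stronger inhibition), where compound 1 gives 545 nM, compound 2 gives 1180 nM and compound 3 gives 6.1 nM. On these numbers compound 1 stands second highest: compound 2 is its nearest neighbour and sits beyond the usual scatter above it, while compound 3 sits far below it. Compound 4 `CCc1nc(-c2ccc(Cl)cc2Cl)c(CC)nc1NC(CC)CC` has not yet been measured in this assay. It differs from compound 1 by ethyl in place of hydrogen on an aromatic carbon. Going by the values given here, no measured pair isolates this change, so the expectation rests on the spread seen so far. The expected step, a 2.2-fold lower number from compound 1 to compound 4 (0.34 log units; beyond the scatter), is a modest move toward stronger inhibition. Compound 4 is estimated at 250 nM, with a range from 80 nM to 800 nM.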

Compound 4, inhibition constant: 4.1 nM
Compound 4: the middle estimate sits 61-fold (1.79 log units) above what was measured; the whole stated range lies above it.
By their numbers in this assay, from the lowest: compounds 4 and 3 (each within the scatter of the next); then compound 1; then compound 2.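

Putting ethyl on this aromatic carbon, ortho to the (pentan-3-yl)amino group and next to the ring nitrogen, gives a 130-fold lower number from compound 1 to compound 4 (2.12 log units; beyond the scatter) in this assay and counts as a large step. The earlier compounds could not show this, as none isolated the position; here a single change of just 2 carbon atoms accounts for the whole gain. Nothing measured here explains why so small an addition has so large an effect.

Still open, going by these compounds, is how this position would respond to methyl, to a longer chain such as propyl, or to an amine, so it cannot yet be said whether ethyl is the best group here.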